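This account rests on a few compounds, and the source may have more. Where it says the series, first, only, none or still open, it means among the compounds named here.

Compound 1 `Cc1noc(-c2nc(C)c3c(c2N)C(=O)N(Cc2ccccc2)C3=O)n1` was tested in a physicochemical assay for solubility, using the shake flask method, in simulated intestinal fluid, measured as kinetic solubility, with a stated time of 2 h, at 25 degrees C, at pH 6.5; a higher number here means a more soluble compound, a lower number a less soluble compound. In this assay compound 1 gives < 5000 nM, which is a limit of the assay rather than a measured number. Two close relatives of compound 1 were measured in the same way. Compound 2 `Cc1noc(-c2nc(C)c3c(c2N)C(=O)N(Cc2ccc(-n4cccn4)cc2)C3=O)n1` gives < 5000 nM, again only a limit. Compound 3 `Cc1noc(-c2nc(C)c3c(c2N)C(=O)N(Cc2ccccc2C(F)(F)F)C3=O)n1` gives < 5000 nM, also a limit. The step that the two limits leave unreadable from compound 1 to compound 2 and the step that the two limits leave unreadable from compound 1 to compound 3 therefore cannot be read in size or direction. The next step leads from compound 1 to compound 4 `Cc1noc(-c2nc(C)c3c(c2N)C(=O)N(Cc2ccc(S(C)(=O)=O)cc2)C3=O)n1`, and the change is methylsulfonyl in place of hydrogen on an aromatic carbon. Among the measured compounds shown here, no measured step bears on this change with a readable size; what is known is the limit of < 5000 nM in this assay, at which 3 of the 3 values shown sit. So no step beyond the scatter can be expected in either direction, and the likeliest outcome is that compound 4 also comes back as a limit. The estimated step is a step that the limit leaves unreadable from compound 1 to compound 4. Compound 4 is expected to give 3000 nM, within a range from 500 nM to 15000 nM.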

Compound 4, solubility: < 5000 nM
Compound 4: no number, only a limit; the forecaster's own chance of this, stated with the estimate: 65%; the middle value is on the limit's open side.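

Compound 4 is again only a limit of the assay, so no step from compound 1, compound 2 or compound 3 to compound 4 can be read in size or direction: the limit of < 5000 nM in this assay, at which 4 of the 4 values shown sit.

The compounds shown leave open whether methylsulfonyl, 1H-pyrazol-1-yl or trifluoromethyl makes any difference in this assay.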